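Trading a branched acid arm for a plain one

The compounds below may be only part of what the source reports. "The series", "measured", "known", "first", "only" and "open" are said of these compounds alone.

Measured so far:
compound 1, `C#CCN(Cc1ccc2nc(C)nc(O)c2c1)c1ccc(C(=O)N[C@@H](CC(C)(C)C(=O)O)C(=O)N[C@@H](CCC(=O)O)C(=O)O)cc1`, gives 18 nM in an assay on L1210 cells for inhibition of Thymidylate synthase (Mus musculus); a lower number here means a stronger inhibitor, a higher number a weaker inhibitor;
compound 2, `Cc1nc(O)c2cc(CN(C)c3ccc(C(=O)N[C@@H](CCC(=O)O)C(=O)N(C)[C@@H](CCC(=O)O)C(=O)O)c(F)c3)ccc2n1`, gives 23 nM;
compound 3, `Cc1nc(O)c2cc(CN(C)c3ccc(C(=O)N[C@@H](CCC(=O)O)C(=O)N(C)[C@@H](CCC(=O)O)C(=O)O)cc3)c(C)cc2n1`, gives 8.2 nM.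

Among these three numbers compound 1 stands second highest. Its nearest neighbour is compound 2, whose number lies within the scatter of that of compound 1, so the two cannot be placed in order; compound 3 lies beyond the scatter, with the lower number of the two.

Compound 4, `C#CCN(Cc1ccc2nc(C)nc(O)c2c1)c1ccc(C(=O)N[C@@H](CCC(=O)O)C(=O)N[C@@H](CCC(=O)O)C(=O)O)cc1`, is not yet measured. It differs from compound 1 by carboxymethyl in place of 1-carboxy-1-methylethyl on a saturated chain carbon, two bonds along the chain from an amide-type nitrogen and a carbonyl carbon. Among the measured compounds shown here, no measured pair shows this change, so its size is open. The estimate for compound 4 is 12 nM, between 4 nM and 40 nM, a step expected to be a 1.5-fold lower number from compound 1 to compound 4 (0.18 log units; within the scatter), within the scatter or modestly toward a lower number.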

Compound 4, inhibition constant: 2 nM
Estimate against measurement, compound 4: 6.0-fold (0.78 log units) above; the whole stated range lies above it.
By their numbers in this assay, from the lowest: compound 4; then compound 3; then compounds 1 and 2 (each within the scatter of the next).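

Carboxymethyl in place of 1-carboxy-1-methylethyl on this saturated chain carbon gives a 9.0-fold lower number from compound 1 to compound 4 (0.95 log units; beyond the scatter) in this assay. Among the compounds shown here, this is the first step read at this position, and it shows that the number responds strongly to the acid arm, with the plain arm giving the lower number. Nothing at hand explains why the step is this large.

The compounds shown leave open how an arm with a single methyl on that chain carbon, or a longer chain ending in the carboxylic acid, would compare. They also leave open whether the same change gives a similar step on the other structures shown, such as compound 2 and compound 3.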